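This account rests on a few compounds, and the source may have more. Where it says the series, first, only, none or still open, it means among the compounds named here.

In an ADME assay on the whole organism (plasma) for pharmacokinetics, with Rattus norvegicus as the target (a lower number here means slower removal, a higher number faster removal of the compound), compound 1 `CC(C)S(=O)(=O)n1cc2c(n1)CN([C@H]1CO[C@H](c3cc(F)ccc3F)[C@@H](N)C1)C2` gives 7 mL/min/kg and compound 2 `N[C@H]1C[C@@H](N2Cc3[nH]nc(NC(=O)C4CC4)c3C2)CO[C@@H]1c1cc(F)ccc1F` gives 64 mL/min/kg as the higher of the two numbers, a gap beyond the scatter. Compound 3 `CCS(=O)(=O)Nc1n[nH]c2c1CN([C@H]1CO[C@H](c3cc(F)ccc3F)[C@@H](N)C1)C2` has ethylsulfonyl in place of cyclopropylcarbonyl on a nitrogen on an aromatic ring. Among the compounds with values here, no measured step isolates this change. The expectation leans on compound 1, which also carries a sulfonyl group and gives 7 mL/min/kg in this assay. The estimated step of a 2.9-fold lower number from compound 2 to compound 3 (0.46 log units; beyond the scatter) is expected to lead to a lower number, beyond the scatter. For compound 3 the estimated clearance is 22 mL/min/kg with 9 mL/min/kg to 55 mL/min/kg as the expected range.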

Compound 3, clearance: 12 mL/min/kg
For compound 3 the middle estimate is 1.8-fold (0.26 log units) above the measured one; the range from low to high includes it.
By their numbers in this assay, from the lowest: compounds 1 and 3 (each within the scatter of the next); then compound 2.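

Within the data shown here, this is the first pair in which only the group on a nitrogen on an aromatic ring changes, and in this assay (cyclopropylcarbonyl)amino to (ethylsulfonyl)amino gives a 5.3-fold lower number from compound 2 to compound 3 (0.73 log units; beyond the scatter). The group at this place therefore moves clearance on its own, with the rest of the structure held fixed. Nothing shown gives a reason for this step. Going by these compounds, the change swaps the ring and the sulfonyl at once, so which of them carries the step stays open. A cyclopropylsulfonyl or a propanoyl group on the same nitrogen would separate the two.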